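Ring expansion of a bicyclic side group in a nitrile series

The source may report more compounds than this note shows. Statements on the series, on what has been measured and on what is new or still open speak of the compounds shown alone.

Three compounds share one core. For compound 1 `N#C[C@@]1(NC(=O)[C@@H](CC(=O)N2CCOCC2)CC2CCC(c3ccccc3)CC2)CCN(C2CCCCC2)C1` the result in an assay on isolated protein for inhibition of cathepsin S (Homo sapiens) (a higher number here means weaker binding, a lower number tighter binding), is "not determined" (no result reported). Compound 2 `CC1CCC(C[C@H](CC(=O)N2CCOCC2)C(=O)N[C@]2(C#N)CCN(C3CCCCC3)C2)CC1` gives 13.8 nM in this assay, and compound 3 `N#C[C@@]1(NC(=O)[C@@H](CC(=O)N2CCOCC2)CC2Cc3ccccc3C2)CCN(C2CCCCC2)C1` gives 23.1 nM. Among the two numbers, compound 3 has the higher one, but the step of a 1.7-fold higher number from compound 2 to compound 3 (0.22 log units; within the scatter) is within the scatter, so the two compounds cannot be told apart on these data.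

Compound 4 `N#C[C@@]1(NC(=O)[C@@H](CC(=O)N2CCOCC2)CC2CCc3ccccc3C2)CCN(C2CCCCC2)C1` differs from compound 3 in one place: 1,2,3,4-tetrahydronaphthalen-2-yl in place of 2,3-dihydro-1H-inden-2-yl on a saturated chain carbon, two bonds along the chain from a carbonyl carbon. For the measured compounds named here, the only measured step at this position, a 1.7-fold higher number from compound 2 to compound 3 (0.22 log units; within the scatter), swapped one saturated ring for a fused bicyclic group with little effect. Enlarging the non-aromatic ring of that bicyclic group by one carbon is a smaller change again, so the expected step of a 1.1-fold lower number from compound 3 to compound 4 (0.02 log units; within the scatter) is one of no clear direction and of a size within the scatter. The estimate for compound 4 in this assay is therefore 22 nM, with a likely range from 8 nM to 60 nM.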

Compound 4, dissociation constant: 5.4 nM
The estimate for compound 4 lay 4.1-fold (0.61 log units) above the measured number, outside the stated range (below it).
By their numbers in this assay, from the lowest: compound 4; then compounds 2 and 3 (each within the scatter of the next).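

Enlarging the non-aromatic ring by one carbon, from 2,3-dihydro-1H-inden-2-yl to 1,2,3,4-tetrahydronaphthalen-2-yl, gives a 4.3-fold lower number from compound 3 to compound 4 (0.63 log units; beyond the scatter) in this assay and so shows that this position responds to a change as small as one ring carbon. Compound 4 also separates from the 4-methylcyclohexyl group, with a 2.6-fold lower number from compound 2 to compound 4 (0.41 log units; beyond the scatter) in this assay, whereas the earlier comparison of compound 2 and compound 3 could not tell two side groups apart. Nothing measured here accounts for the lower number of compound 4.

Compound 1 has no reported result, so its steps cannot be read. On these data alone, it also remains open whether a seven-membered non-aromatic ring in the same bicyclic group, or an amine or a carboxylic acid on its aromatic ring, would lower the number further or raise it.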